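The source may report more compounds than this note shows. Statements on the series, on what has been measured and on what is new or still open speak of the compounds shown alone.

Working notes on the series: in a functional assay on HCT-15 cells (Homo sapiens) for cytotoxicity (a higher number here means a weaker inhibitor, a lower number a stronger inhibitor), compound 3 `COc1ccc(-c2cc3c(N(C)C)cccc3c(N3CCN(C)CC3)n2)cc1` gives 6170 nM. Compound 2 `CN1CCN(c2nc(-c3ccc(Cl)cc3)cc3c(N(C)C)cccc23)CC1` gives 7980 nM, within the scatter of that number, while compound 1 `Cc1ccc2c(O)nc(-c3ccccc3C)cc2c1` gives a higher 30900 nM. Compound 4 `CN1CCN(c2nc(-c3ccccc3)cc3c(N(C)C)cccc23)CC1` follows from compound 3 by hydrogen in place of methoxy on an aromatic carbon, so 4-methoxyphenyl becomes phenyl. Among the measured compounds shown here, the one measured step at that carbon, a 1.3-fold lower number from compound 2 to compound 3 (0.11 log units; within the scatter), methoxy in place of chloro, stays within the scatter, so no step beyond the scatter is expected in this assay, although no measured compound yet carries hydrogen there. The expected change is a 1.1-fold higher number from compound 3 to compound 4 (0.05 log units; within the scatter). For compound 4 the estimated value is 7000 nM, with an expected range of 3300 nM to 15000 nM.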

Compound 4, half-maximal inhibitory concentration: 20000 nM
Compound 4: the middle estimate sits 2.9-fold (0.46 log units) below what was measured, outside the stated range (above it).
By their numbers in this assay, from the lowest: compounds 3 and 2 (each within the scatter of the next); then compounds 4 and 1 (each within the scatter of the next).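

In this assay the carbon para to a large group responds to losing its substituent: methoxy to hydrogen gives a 3.2-fold higher number from compound 3 to compound 4 (0.51 log units; beyond the scatter) and chloro to hydrogen gives a 2.5-fold higher number from compound 2 to compound 4 (0.40 log units; beyond the scatter) while methoxy and chloro stay within the scatter of each other. In these three compounds, either group gives a lower number than hydrogen, which the chloro-to-methoxy step alone could not show. No measurement here bears on the reason. Open, from the compounds shown here alone, is whether an amine or a longer chain such as butoxy at this carbon matches methoxy and chloro or matches hydrogen.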